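The source may hold more compounds than are shown below. What is called first, only, known or untested is meant among the compounds shown, and "the series" means these compounds.

Measured in a functional assay, with a stated time of 10 min; on this read-out higher numbers stand for weaker inhibition and lower numbers for stronger inhibition:
- compound 1 `O=c1cc(/C=C/c2ccccc2)[nH]cc1O`: 4030 nM
- compound 2 `O=c1cc(/C=C/c2ccc(Cl)cc2)[nH]cc1O`: 11500 nM
- compound 3 `O=c1cc(/C=C/c2cccc(F)c2)[nH]cc1O`: 6290 nM

Among these three, compound 3 at 6290 nM lies within the usual scatter of both compound 1 and compound 2, although those two differ from each other by more than the scatter. The next compound is compound 4 `Cn1cc(O)c(=O)cc1/C=C/c1cccc(F)c1`, which has not yet been measured. It differs from compound 3 by one change: methyl in place of hydrogen on an aromatic nitrogen. In words, this is methyl in place of hydrogen on an aromatic nitrogen.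

Among the measured compounds shown here, only two measured steps are available, and both are changes on an aromatic carbon. The chloro step is a 2.9-fold higher number from compound 1 to compound 2 (0.46 log units; beyond the scatter), a modest one. The fluoro step is a 1.6-fold higher number from compound 1 to compound 3 (0.19 log units; within the scatter), which stays within the scatter. Neither step touches the aromatic nitrogen, so they show only that single substitutions in this small set have so far moved this assay modestly. Going by these compounds, no measurement shows what a methyl on that nitrogen does, so the direction remains open and the range must be wide. The working expectation is no change beyond the scatter, and the expected step is a 1.0-fold lower number from compound 3 to compound 4 (0.02 log units; within the scatter). For compound 4 the estimated value is 6000 nM, with an expected range from 1800 nM to 20000 nM.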

Compound 4, half-maximal inhibitory concentration: 1310 nM
Compound 4: middle estimate off by 4.6-fold (0.66 log units), on the high side; measured number outside the range, below it.
By their numbers in this assay, from the lowest: compound 4; then compounds 1, 3 and 2 (each within the scatter of the next, the first and the last beyond it).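

In this assay, among the compounds shown here, methyl in place of hydrogen on an aromatic nitrogen gives a 4.8-fold lower number from compound 3 to compound 4 (0.68 log units; beyond the scatter), the only single change in this small set that lowers the number beyond the scatter. The earlier changes, both on an aromatic carbon, did not do this: chloro gave a 2.9-fold higher number from compound 1 to compound 2 (0.46 log units; beyond the scatter), and fluoro gave a 1.6-fold higher number from compound 1 to compound 3 (0.19 log units; within the scatter), which stays within the scatter. The pair therefore shows that this nitrogen is a position where a substituent can be placed without loss in this read-out, and that the hydrogen on it is not needed for inhibition in this compound, although nothing available accounts for the size or direction of the step.

Whether the nitrogen accepts more than a methyl remains open, since a longer chain such as ethyl or propyl, or a chain ending in an amine or a carboxylic acid, does not appear among these compounds. For the compounds shown here, it is also open whether the methyl gives a comparable step without the fluoro group or alongside the chloro group, as this change is seen on only one pair.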